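This account rests on a few compounds, and the source may have more. Where it says the series, first, only, none or still open, it means among the compounds named here.

Values in a functional assay (muscle tissue) with Cavia porcellus as the target; on this read-out lower numbers stand for an effect already at smaller amounts and higher numbers for an effect only at larger amounts of compound:
- compound 1 `COC(=O)C1=C(C)N=C(C)/C(=C(\O)OC)C1c1cccc(N)c1`: 2000 nM
- compound 2 `COC(=O)C1=C(C)N=C(C)/C(=C(\O)OC)C1c1ccccc1Br`: 7.59 nM

Compound 2, at 7.59 nM, holds the lower of the two numbers. Compound 3 `COC(=O)C1=C(C)N=C(C)/C(=C(\O)OC)C1c1cccc(C#N)c1` keeps the shared core but carries 3-cyanophenyl in place of 2-bromophenyl on a saturated ring carbon. Within the data shown here, one measured step bears on this place: a 260-fold lower number from compound 1 to compound 2 (2.42 log units; beyond the scatter). That large step shows that swapping this group can move the number strongly, but no nitrile has been measured yet. A moderate move towards a higher number is therefore expected in this assay, smaller than that step, and the estimate is a 5.3-fold higher number from compound 2 to compound 3 (0.72 log units; beyond the scatter). For compound 3 the expected value is 40 nM, with an estimated range of 8 nM to 250 nM.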

Compound 3, half-maximal effective concentration: 34.7 nM
Compound 3: the middle estimate sits 1.2-fold (0.06 log units) above what was measured, within the range that was stated.
By their numbers in this assay, from the lowest: compound 2; then compound 3; then compound 1.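

In this assay, 3-cyanophenyl stays much closer to 2-bromophenyl than 3-aminophenyl does, with a 4.6-fold higher number from compound 2 to compound 3 (0.66 log units; beyond the scatter) as a modest step. With a 58-fold lower number from compound 1 to compound 3 (1.76 log units; beyond the scatter) as a large step, changing amino to cyano on an aromatic carbon shows that the group itself can strongly move the number, even when the rest of the compound stays the same. Nothing measured here explains either step. Going by these compounds, the step from 2-bromophenyl to 3-cyanophenyl changes the group and its place on the phenyl ring together, so their separate shares remain open. On these data alone, how a carboxylic acid or a methoxy group would compare also remains open.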